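Chloro in place of hydrogen, compound 2 to compound 4

This account rests on a few compounds, and the source may have more. Where it says the series, first, only, none or still open, it means among the compounds named here.

Values in an ADME assay on microsomes from liver (Rattus norvegicus) for metabolic stability, with a stated time of 10 min (on this read-out higher numbers stand for a more stable compound and lower numbers for a less stable compound), so far:
- compound 1 `FC(F)(F)c1ccccc1-c1cc(Cl)c2[nH]c(C3=NOC4(CCCCC4)C3)nc2c1` gives 100%
- compound 2 `FC(F)(F)c1ccccc1-c1ccc2[nH]c(C3=NOC4(CCOCC4)C3)nc2c1` gives 74%
- compound 3 `FC1(F)CCC2(CC1)CC(c1nc3cc(-c4ccccc4C(F)(F)F)ccc3[nH]1)=NO2` gives "not determined" (no result reported)

Of the two numbers, the lower belongs to compound 2 at 74% and the higher to compound 1 at 100%, a gap beyond the scatter. Compound 3 supplies no number.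

The next compound is compound 4 `FC(F)(F)c1ccccc1-c1cc(Cl)c2[nH]c(C3=NOC4(CCOCC4)C3)nc2c1`, which differs from compound 2 by chloro in place of hydrogen on an aromatic carbon and has chloro in place of hydrogen on an aromatic carbon, ortho to a fused ring. Going by the values given here, no measured pair shows this change alone. Compound 1 also carries chloro and stands at 100% in this assay, but it differs from compound 2 elsewhere too, so it offers only a weak hint.

A small upward move, about the size of the scatter, is expected, with the estimated step being a number 9 percentage points higher from compound 2 to compound 4 (within the scatter) in this assay. For compound 4 the estimated value is 83%, with an expected range from 66% to 98%.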

Compound 4, percent of the compound remaining: 82%
For compound 4 the middle estimate is 1 percentage points above the measured one; the range from low to high includes it.
By their numbers in this assay, from the lowest: compounds 2 and 4 (each within the scatter of the next); then compound 1.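

In this assay, chloro in place of hydrogen on an aromatic carbon, ortho to a fused ring, can now be read as a single change: a number 8 percentage points higher from compound 2 to compound 4 (within the scatter), so this exchange alone gives no clear separation. With chloro held constant, the six-membered non-aromatic ring also gets its first single-change reading: a number 18 percentage points lower from compound 1 to compound 4 (beyond the scatter), with the ring of carbon only on the compound 1 side and the ring with 1 hetero atom on the compound 4 side. No measurement here accounts for either step.

As far as these compounds go, whether a nitrile or a methoxy group at the same aromatic carbon would read like chloro remains open. Also open, from the compounds shown here alone, is how an amine on the six-membered non-aromatic ring, or the two fluorines of compound 3, would read in this assay.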